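The source may hold more compounds than are shown below. What is called first, only, known or untested is meant among the compounds shown, and "the series" means these compounds.

Working notes on the series. Compound 1 is `COc1cccc(/C=C/C(=O)c2sc(Nc3cccc(C)c3)nc2C)c1`. In a functional assay on BGC-823 cells (Homo sapiens) for cytotoxicity, read by MTT assay (a higher number here means a weaker inhibitor, a lower number a stronger inhibitor), compound 1 gives > 25000 nM, which is a limit of the assay rather than a number. Compound 2 is `COc1cccc(/C=C/C(=O)c2sc(Nc3ccc(Cl)cc3)nc2C)c1`. In this assay compound 2 gives > 25000 nM, again a limit. The step from compound 1 to compound 2 is a step that the two limits leave unreadable from compound 1 to compound 2, so its size cannot be read. Compound 3 is `Cc1ccccc1Nc1nc(C)c(C(=O)/C=C/c2ccc(Cl)cc2)s1`. In this assay compound 3 gives > 25000 nM, also a limit. Among the compounds with values here, compound 3 thus stands where every measured member of the series stands, namely at the limit of > 25000 nM in this assay, at which 3 of the 3 values shown sit, and no step among the measured compounds has a readable size.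

Compound 4 is `COc1cccc(/C=C/C(=O)c2sc(Nc3ccccc3C)nc2C)c1`. Against compound 3 the change is 3-methoxyphenyl in place of 4-chlorophenyl on a double-bonded chain carbon bound to a double-bonded chain carbon. Within the data shown here, no measured step bears on this change: the only step between measured compounds, a step that the two limits leave unreadable from compound 1 to compound 2, alters the group on the nitrogen and is itself unreadable, while the entering 3-methoxyphenyl group is already present on the chain of compound 1 and compound 2, both of which sit at the limit of > 25000 nM in this assay, at which 3 of the 3 values shown sit. Nothing seen so far supports a step beyond the scatter in either direction in this assay. The step from compound 3 to compound 4 is therefore expected to be a step that the limit leaves unreadable from compound 3 to compound 4. Compound 4 is estimated at 30000 nM, in the range 10000 nM to 100000 nM, and is most likely to be reported as a limit once more.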

Compound 4, half-maximal inhibitory concentration: > 25000 nM
Compound 4: no number, only a limit (the forecaster's own chance of this, stated with the estimate: 75%); the middle value lies beyond the limit too.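

In this assay compound 4 gives a limit and not a number, so the steps to compound 4 from compound 1, compound 2 and compound 3 cannot be read: the limit of > 25000 nM in this assay, at which 4 of the 4 values shown sit. The compounds shown leave open the size and direction of the effect of each change, whether on the nitrogen or on the chain.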